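This account rests on a few compounds, and the source may have more. Where it says the series, first, only, none or still open, it means among the compounds named here.

Three compounds of one series have been run through a functional assay on A549 cells (Homo sapiens) for inhibition, read by MTT assay, with a stated time of 72 h, tested at 20 uM; on this read-out lower numbers stand for less inhibition and higher numbers for more inhibition at the one concentration tested (going by the name of the read-out). Compound 1 `c1cc(N2CCCCC2)nc(Nc2ccc(Oc3ncnc4sccc34)cc2)n1` gives 64.8% in this assay, compound 2 `c1ccc2c(c1)CCN(c1ccnc(Nc3ccc(Oc4ncnc5ccsc45)cc3)n1)C2` gives 54.9%, and compound 3 `c1cc(N2CCCC2)nc(Nc2ccc(Oc3ncnc4sccc34)cc2)n1` gives 61%. Compound 3 thereby stands second of the three numbers, separated from compound 1 and from compound 2 only by gaps within the scatter, so no order among them can be claimed. Among the compounds with values here, the one single-place step measured so far, a number 3.8 percentage points lower from compound 1 to compound 3 (within the scatter), is the exchange of one saturated ring for another and lies within the scatter.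

The next compound, compound 4 `c1ccc2c(c1)CCN(c1ccnc(Nc3ccc(Oc4ncnc5sccc45)cc3)n1)C2`, differs from compound 3 by 1,2,3,4-tetrahydroisoquinolin-2-yl in place of pyrrolidin-1-yl on an aromatic carbon. Within the data shown here, no measured step bears directly on this change; the nearest guide is compound 2, which carries the same 1,2,3,4-tetrahydroisoquinolin-2-yl group on a different core and gives a value within the scatter of compound 3. Compound 4 is therefore expected to show a number 4 percentage points lower from compound 3 to compound 4 (within the scatter), a step not beyond the scatter. Compound 4 is estimated at 57%, with a range from 42% to 70%.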

Compound 4, a percentage reported as inhibition, at one concentration (the size of the read-out at that concentration, not a potency): 34%
For compound 4 the middle estimate is 23 percentage points above the measured one; the measured number lies below the stated range.
By their numbers in this assay, from the lowest: compound 4; then compounds 2, 3 and 1 (each within the scatter of the next).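

In this assay, the aromatic carbon next to the ring nitrogen had so far shown only a number 3.8 percentage points lower from compound 1 to compound 3 (within the scatter), but it proves sensitive to the group it carries: 1,2,3,4-tetrahydroisoquinolin-2-yl gives a number 27 percentage points lower from compound 3 to compound 4 (beyond the scatter) in place of pyrrolidin-1-yl and a number 30.8 percentage points lower from compound 1 to compound 4 (beyond the scatter) in place of piperidin-1-yl. The group on the oxygen matters as well, since with 1,2,3,4-tetrahydroisoquinolin-2-yl kept in place, exchanging it alone gives a number 20.9 percentage points lower from compound 2 to compound 4 (beyond the scatter). Nothing available explains either drop.

Going by these compounds, it remains open whether a morpholin-4-yl group or an open-chain dimethylamino group at this carbon would read like compound 1 and compound 3 or like compound 4. On these data alone, it is also open how pyrrolidin-1-yl and piperidin-1-yl would read on the core of compound 2.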